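Methoxy in place of oxazolyl on the amide nitrogen

The compounds below may be only part of what the source reports. "The series", "measured", "known", "first", "only" and "open" are said of these compounds alone.

Measured so far in an assay on HEK293 cells for agonist activity at transient receptor potential cation channel subfamily M member 8 (Homo sapiens), read by fluorescence and calcium flux, with a stated time of 15 min; a lower number here means that less compound is needed, a higher number that more compound is needed for the effect:
- compound 1 `Cc1ccc(OCC(=O)N(Cc2cccs2)c2cccnc2)cc1`: 198 nM
- compound 2 `Cc1ccc(OCC(=O)N(Cc2cccs2)CC(C)C)cc1`: 900 nM
- compound 3 `Cc1ccc(OCC(=O)N(Cc2cccs2)c2ncco2)cc1`: 0.3 nM

All three share one core, and they differ only in the group on the amide-type nitrogen. Compound 3 stands lowest of the three numbers in this assay. The gap to its nearest neighbour is a 660-fold lower number from compound 1 to compound 3 (2.82 log units; beyond the scatter), and the gap to the furthest is a 3000-fold lower number from compound 2 to compound 3 (3.48 log units; beyond the scatter); the two non-oxazolyl compounds lie closer to each other, with a 4.5-fold higher number from compound 1 to compound 2 (0.66 log units; beyond the scatter).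

Compound 4 `CON(Cc1cccs1)C(=O)COc1ccc(C)cc1` is not yet measured. It differs from compound 3 in one place: methoxy in place of 1,3-oxazol-2-yl on an amide-type nitrogen. Among the compounds with values here, the steps that bear on this are those into compound 3, both of which are large: a five-membered aromatic ring with two hetero atoms on the nitrogen gives a far lower number than either pyridin-3-yl or isobutyl. Methoxy, like isobutyl, carries no ring, so a large step upward is expected, a 1700-fold higher number from compound 3 to compound 4 (3.22 log units; beyond the scatter). For compound 4 the estimate in this assay is 500 nM, with a range from 50 nM to 5000 nM.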

Compound 4, half-maximal effective concentration: 10 nM
Compound 4: middle estimate off by 50-fold (1.70 log units), on the high side; the whole stated range lies above it.
By their numbers in this assay, from the lowest: compound 3; then compound 4; then compound 1; then compound 2.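

In this assay, within the data shown here, the ringless methoxy shows that a ring on the amide-type nitrogen is not needed for a low number, a point the earlier compounds could not make: the change gives a 20-fold lower number from compound 1 to compound 4 (1.30 log units; beyond the scatter) against pyridin-3-yl and a 90-fold lower number from compound 2 to compound 4 (1.95 log units; beyond the scatter) against isobutyl, the other ringless group. Having a ring therefore does not by itself sort these compounds, although 1,3-oxazol-2-yl keeps the lowest number, with a 33-fold higher number from compound 3 to compound 4 (1.52 log units; beyond the scatter). Nothing measured here accounts for the order of these four groups.

Going by these compounds, it remains open whether the oxygen of methoxy matters, which an ethyl or ethoxy group on this nitrogen would help to test. On these data alone, it is also open whether the low number of compound 3 extends to other five-membered aromatic rings, such as 1,3-thiazol-2-yl.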